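Halogen steps in the series: compound 2 to compound 3

The source may hold more compounds than are shown below. What is called first, only, known or untested is meant among the compounds shown, and "the series" means these compounds.

- compound 1 `Cn1c(N2N=C(c3ccccc3)CC2c2ccccc2)nc(-c2ccccc2)c(C#N)c1=O`: 3990 nM
- compound 2 `Cn1c(N2N=C(c3ccccc3)CC2c2ccccc2)nc(-c2ccc(Cl)cc2)c(C#N)c1=O`: 29100 nM

In a functional assay on MDA-MB-231 cells (Homo sapiens) for antiproliferative activity, with a stated time of 72 h (on this read-out lower numbers stand for stronger inhibition and higher numbers for weaker inhibition), compound 2 holds the higher of the two numbers. Compound 3 `Cn1c(N2N=C(c3ccccc3)CC2c2ccc(F)cc2)nc(-c2ccc(Cl)cc2)c(C#N)c1=O` differs from it by fluoro in place of hydrogen on an aromatic carbon, phenyl to 4-fluorophenyl. Going by the values given here, the only measured step that bears on this is a 7.3-fold higher number from compound 1 to compound 2 (0.86 log units; beyond the scatter), also a halogen for hydrogen on an aromatic carbon, but at another place. That single step fixes no direction, so no step beyond the scatter is expected in this assay, though with wide uncertainty. For compound 3 the estimated value is 20000 nM, with an expected range of 6000 nM to 60000 nM. The expected step is a 1.5-fold lower number from compound 2 to compound 3 (0.16 log units; within the scatter).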

Compound 3, half-maximal inhibitory concentration: 20900 nM
Estimate against measurement, compound 3: 1.0-fold (0.02 log units) below; low and high end bracket the measured number.
By their numbers in this assay, from the lowest: compound 1; then compounds 3 and 2 (each within the scatter of the next).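

In this assay, fluoro in place of hydrogen at this position gives a 1.4-fold lower number from compound 2 to compound 3 (0.14 log units; within the scatter), so with the chloro group kept elsewhere, phenyl to 4-fluorophenyl leaves the read-out within the scatter. Going by these compounds alone, the earlier halogen step, a 7.3-fold higher number from compound 1 to compound 2 (0.86 log units; beyond the scatter), therefore has no counterpart here, although the halogen differs as well as the place. Nothing available explains this outcome.

Still open, from the compounds shown here alone, is whether chloro, methoxy or an amine at this position would also stay within the scatter. Also open, going by these compounds, is whether fluoro behaves the same without the chloro group elsewhere.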